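This account rests on a few compounds, and the source may have more. Where it says the series, first, only, none or still open, it means among the compounds named here.

Measured in a functional assay on HepG2 cells (Homo sapiens) for cytotoxicity, read by MTT assay, with a stated time of 24 h; on this read-out higher numbers stand for weaker inhibition and lower numbers for stronger inhibition:
compound 1 `O=C1/C(=C/c2ccncc2)CN(S(=O)(=O)c2ccc(C(F)(F)F)cc2)C/C1=C\c1ccccc1F`: 4030 nM
compound 2 `O=C1/C(=C/c2ccncc2)CN(S(=O)(=O)c2ccc(F)cc2)C/C1=C\c1ccccc1F`: 20300 nM
compound 3 `O=C1/C(=C/c2ccncc2)CN(S(=O)(=O)c2ccc(Br)cc2)C/C1=C\c1ccccc1F`: 9300 nM

Compound 2 carries the highest number of the three. Compound 4 `O=C1/C(=C/c2ccncc2)CN(S(=O)(=O)c2ccc(F)cc2)C/C1=C\c1ccccc1C(F)(F)F` is not yet measured. It differs from compound 2 in having 2-(trifluoromethyl)phenyl in place of 2-fluorophenyl: trifluoromethyl in place of fluoro on an aromatic carbon. The nearest evidence comes from another aromatic carbon, where the same two groups show a 5.0-fold higher number from compound 1 to compound 2 (0.70 log units; beyond the scatter), the reverse exchange. Also at that carbon, a 2.2-fold lower number from compound 2 to compound 3 (0.34 log units; beyond the scatter). On these data alone, whether either step carries over to the new place is untested, so only part of the first is assumed. A modest move to a lower number is expected, a 2.3-fold lower number from compound 2 to compound 4 (0.35 log units; beyond the scatter). For compound 4 the estimated value is 9000 nM, with an expected range of 3500 nM to 22000 nM.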

Compound 4, half-maximal inhibitory concentration: 4010 nM
For compound 4 the middle estimate is 2.2-fold (0.35 log units) above the measured one; measured number inside the range.
By their numbers in this assay, from the lowest: compounds 4 and 1 (each within the scatter of the next); then compound 3; then compound 2.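

In this assay, 2-(trifluoromethyl)phenyl in place of 2-fluorophenyl gives a 5.1-fold lower number from compound 2 to compound 4 (0.70 log units; beyond the scatter). The exchange therefore acts in the same direction at this second aromatic carbon as at the first, where the reverse exchange gives a 5.0-fold higher number from compound 1 to compound 2 (0.70 log units; beyond the scatter), and the two steps are of similar size. Nothing available explains this match between the two places.

The compounds shown leave open how bromo, methoxy or an amine would read at this place. Also open, on these data alone, is whether trifluoromethyl at both places would lower the number further.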